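Moving a nitro group around a sulfonyl-bound ring

The source may hold more compounds than are shown below. What is called first, only, known or untested is meant among the compounds shown, and "the series" means these compounds.

- compound 1 `COc1ccc(Cc2nnc(NC(=O)/C(C#N)=C/c3ccccc3OS(=O)(=O)c3ccccc3[N+](=O)[O-])s2)cc1` gives 25%
- compound 2 `COc1ccc(S(=O)(=O)Oc2ccccc2/C=C(\C#N)C(=O)Nc2nnc(Cc3ccc(Cl)cc3)s2)cc1` gives 99%
- compound 3 `N#C/C(=C\c1ccccc1OS(=O)(=O)c1ccc([N+](=O)[O-])cc1)C(=O)Nc1nnc(Cc2ccc(Cl)cc2)s1` gives 34%

Within the data shown here, in a functional assay on HL-60 cells (Homo sapiens) for inhibition, read by CCK-8 assay, with a stated time of 48 h, tested at 20 uM (a higher number here means more inhibition of growth at the concentration tested, a lower number less inhibition of growth), compound 3 (34%) lies within the scatter of compound 1 (25%) and far under compound 2 (99%) on the numbers so far.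

Compound 4 `N#C/C(=C\c1ccccc1OS(=O)(=O)c1ccccc1[N+](=O)[O-])C(=O)Nc1nnc(Cc2ccc(Cl)cc2)s1` has the same atoms as compound 3, joined differently: 2-nitrophenyl in place of 4-nitrophenyl on a sulfonyl sulfur and so 2-nitrophenyl stands in place of 4-nitrophenyl on a sulfonyl sulfur.

Among the measured compounds shown here, the only measured step of a number 65 percentage points lower from compound 2 to compound 3 (beyond the scatter) was large and beyond the scatter, but it replaced methoxy with nitro, whereas compound 4 keeps its nitro group. For the measured compounds named here, no measured step covers this exact change. Compound 1 also carries 2-nitrophenyl on a sulfonyl sulfur and gives 25% with a different group elsewhere in the molecule. In this assay no step beyond the scatter is therefore expected, although this rests on little data.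

The expected change is a number 2 percentage points lower from compound 3 to compound 4 (within the scatter) as an estimate only.

For compound 4 the estimated value is 32% with an expected range from 12% to 60% in this measurement.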

Compound 4, percent growth inhibition at one concentration: 19%
Compound 4: the middle estimate sits 13 percentage points above what was measured, and the stated range covers the measured number.
By their numbers in this assay, from the lowest: compounds 4, 1 and 3 (each within the scatter of the next, the first and the last beyond it); then compound 2.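

In this assay, among these compounds, the 4-nitrophenyl to 2-nitrophenyl change on a sulfonyl sulfur is the first step here that moves only the nitro group, and a number 15 percentage points lower from compound 3 to compound 4 (beyond the scatter) shows that its placement has a measurable but modest effect. The change from 4-methoxyphenyl to 2-nitrophenyl is far larger at a number 80 percentage points lower from compound 2 to compound 4 (beyond the scatter), so among these compounds, the swap away from 4-methoxyphenyl outweighs the nitro shift. With 2-nitrophenyl kept, chloro in place of methoxy on the other aromatic ring gives a number 6 percentage points lower from compound 1 to compound 4 (within the scatter), so that change cannot be told from the usual scatter.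

Going by these compounds, it remains open whether the high reading of compound 2 at 99% is specific to methoxy or would also appear with an amine or an ethoxy group on the ring attached to the sulfonyl sulfur. Nothing available here explains why these groups differ.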